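A Second Methoxy Group and Its Cost in Potency

This account rests on a few compounds, and the source may have more. Where it says the series, first, only, none or still open, it means among the compounds named here.

Compound 1 `COc1ccc(/C=C/C(=O)c2ccccc2-c2ccc(OC)c(OC)c2)cc1` gives 320 nM in a functional assay on CNE-2 cells (Homo sapiens) for antiproliferative activity, read by sulforhodamine B assay, with a stated time of 48 h; on this read-out lower numbers stand for stronger inhibition and higher numbers for weaker inhibition.
Compound 2 `COc1ccc(/C=C/C(=O)c2ccccc2-c2ccc(OC)c(OC)c2)cc1OC` gives 2500 nM in this assay.
Compound 3 `COc1ccc(/C=C/C(=O)c2ccccc2-c2cccc(F)c2)cc1` gives 73 nM in this assay.

Compound 2 differs from compound 1 by methoxy in place of hydrogen on an aromatic carbon, and the result is a 7.8-fold higher number from compound 1 to compound 2 (0.89 log units; beyond the scatter). Compound 3 stands lowest of the three, with its steps to compound 1 and to compound 2 both beyond the scatter, so it is the most potent of the measured set in this assay. The difference between the core of compound 3 and the core of compound 1 is not broken down here.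

Compound 4 `COc1ccc(/C=C/C(=O)c2ccccc2-c2cccc(F)c2)cc1OC` has not yet been measured. It differs from compound 3 by methoxy in place of hydrogen on an aromatic carbon, the same change as that from compound 1 to compound 2, made on the same kind of place. Because a 7.8-fold higher number from compound 1 to compound 2 (0.89 log units; beyond the scatter), the expected step is a 6.8-fold higher number from compound 3 to compound 4 (0.84 log units; beyond the scatter), a weakening of about the same size. On that basis compound 4 is estimated at 500 nM in this assay, expected to lie between 150 nM and 1600 nM.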

Compound 4, half-maximal inhibitory concentration: 650 nM
Compound 4: middle estimate off by 1.3-fold (0.11 log units), on the low side; the range from low to high includes it.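

The same methoxy change, made on a second core, weakens the result in this assay much as it did on the first, with an 8.9-fold higher number from compound 3 to compound 4 (0.95 log units; beyond the scatter), and the two steps agree: the same change on two cores in this assay, a 7.8-fold higher number (0.89 log units; beyond the scatter) from compound 1 to compound 2 and an 8.9-fold higher number (0.95 log units; beyond the scatter) from compound 3 to compound 4, 1.1-fold (0.06 log units) apart, within the scatter of two such steps. Among the compounds that carry this methoxy group, 3-fluorophenyl in place of 3,4-dimethoxyphenyl gives a 3.8-fold lower number from compound 2 to compound 4 (0.59 log units; beyond the scatter), so the core still matters while the cost of the change stays about the same on both. This rests on two pairs alone, and it shows neither that the step would keep its size on a further core nor why it has this size.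

The compounds shown leave open whether another group at the same place, such as an ethoxy group, a hydroxyl or a fluorine, would carry a similar cost. They also leave open how the step would behave with an amine or a carboxylic acid elsewhere on the core.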